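The compounds below may be only part of what the source reports. "The series", "measured", "known", "first", "only" and "open" are said of these compounds alone.

Measured compounds:
- Compound 1 `O=C1c2c[n+]([O-])c3ccccc3c2C(=O)c2c1c1ccccc1n2Cc1cn([C@H]2O[C@H](CO)[C@@H](O)[C@H]2O)nn1`: in a functional assay on MCF7 cells (Homo sapiens) for cytotoxicity, read by MTT assay, with a stated time of 72 h (on this read-out higher numbers stand for weaker inhibition and lower numbers for stronger inhibition), compound 1 gives 1490 nM.
- Compound 2 `O=C1c2c[n+]([O-])c3ccccc3c2C(=O)c2c1c1ccccc1n2CCCCn1ccnc1`: in this assay compound 2 gives 130 nM.
- Compound 3 `O=C1c2c[n+]([O-])c3ccccc3c2C(=O)c2c1c1ccccc1n2Cc1cn(C[C@H](O)CO)nn1`: in this assay compound 3 gives only a limit, > 1000 nM.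

Compound 3 thus stands only as a limit on the numbers shown, with no read number of its own (the limit of > 1000 nM in this assay, at which 1 of the 3 values shown sits). The step that the limit leaves unreadable from compound 1 to compound 3 cannot be sized for that reason. The step of an at least 7.6-fold higher number from compound 2 to compound 3 (0.88 log units; beyond the scatter) can be read in one direction only: the chain ending in a ring bound through nitrogen gave the markedly lower number.

Compound 4 `CN1CCN(CCCCn2c3c(c4ccccc42)C(=O)c2c[n+]([O-])c4ccccc4c2C3=O)CC1` differs from compound 3 by 3-(4-methylpiperazin-1-yl)propyl in place of 1-(2,3-dihydroxypropyl)-1H-1,2,3-triazol-4-yl on a saturated chain carbon bound to an aromatic nitrogen. The entering group, 3-(4-methylpiperazin-1-yl)propyl, resembles the 3-(1H-imidazol-1-yl)propyl of compound 2 far more than the 1-(2,3-dihydroxypropyl)-1H-1,2,3-triazol-4-yl it replaces, so the step from compound 2 to compound 3 is the one that bears here, and its reverse is expected. The expected step is an at least 5.0-fold lower number from compound 3 to compound 4 (0.69 log units; beyond the scatter). Compound 4 is therefore expected to give about 200 nM, within 60 nM to 800 nM.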

Compound 4, half-maximal inhibitory concentration: 100 nM
Beside the measured number, compound 4's estimate is 2.0-fold (0.30 log units) above it; the range from low to high includes it.
By their numbers in this assay, from the lowest: compounds 4 and 2 (each within the scatter of the next); then compound 1.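

Placing 3-(4-methylpiperazin-1-yl)propyl on a saturated chain carbon bound to an aromatic nitrogen, in place of 1-(2,3-dihydroxypropyl)-1H-1,2,3-triazol-4-yl, gave an at least 10-fold lower number from compound 3 to compound 4 (1.00 log units; beyond the scatter), so a second chain ending in a ring bound through nitrogen now reads low in this assay. The 4-methylpiperazin-1-yl and 1H-imidazol-1-yl ends cannot be told apart on this chain, with a 1.3-fold lower number from compound 2 to compound 4 (0.11 log units; within the scatter). Compound 3 still stands as a limit and not as a number, so the first step gives only a minimum size: the limit of > 1000 nM in this assay, at which 1 of the 4 values shown sits.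

The compounds shown leave open whether the chain end needs a ring at all, which a plain dimethylamino group or a carboxylic acid in the same place would address. They also leave open whether a shorter or longer chain carrying 4-methylpiperazin-1-yl would read the same.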